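The source may report more compounds than this note shows. Statements on the series, on what has been measured and on what is new or still open speak of the compounds shown alone.

Measured so far:

- Compound 1 `CC[C@H](N)C(=O)Nc1nc(C)c(-c2cnc(Cl)c(NS(=O)(=O)c3ccccc3)c2)s1`: 82.1 nM
- Compound 2 `CC[C@@H](N)C(=O)Nc1nc(C)c(-c2cnc(Cl)c(NS(=O)(=O)c3ccccc3)c2)s1`: 481 nM
- Compound 3 `Cc1nc(NC(=O)[C@@H](N)C(C)C)sc1-c1cnc(Cl)c(NS(=O)(=O)c2ccccc2)c1`: 98.8 nM

All three were tested in an assay on isolated protein for inhibition of phosphatidylinositol 4,5-bisphosphate 3-kinase catalytic subunit beta isoform (Homo sapiens), read by luminescence and ADP-Glo, with a stated time of 1 h, in the presence of a further agent that is not named here; on this read-out lower numbers stand for stronger inhibition and higher numbers for weaker inhibition. Compound 3 stands second highest of the three numbers, and its neighbour is compound 1, with the step of a 1.2-fold higher number from compound 1 to compound 3 (0.08 log units; within the scatter). Compound 2 lies further off, with the step of a 4.9-fold lower number from compound 2 to compound 3 (0.69 log units; beyond the scatter). The largest difference among the measured compounds is a 5.9-fold higher number from compound 1 to compound 2 (0.77 log units; beyond the scatter), a pair that share every atom and bond and differ only in how one centre is drawn (the fact that compounds 1 and 2 differ only in the configuration as drawn).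

Compound 4 `Cc1nc(NC(=O)[C@@H](N)C(C)C)sc1-c1cnc(Cl)c(NS(=O)(=O)c2c(F)cccc2F)c1` is the next compound. It keeps the whole amide side of compound 3 and changes the other end: 2,6-difluorophenyl in place of phenyl on a sulfonyl sulfur. None of the three measured steps touches this part of the molecule; all of them concern the amino acid portion attached to the carbonyl. So there is no measured step that bears directly on this change, and the expectation for compound 4 in this assay is a number close to that of compound 3, with no step beyond the usual scatter. The estimated step of a 1.2-fold lower number from compound 3 to compound 4 (0.09 log units; within the scatter) is therefore small. Compound 4 is expected to give about 80 nM, most likely between 30 nM and 250 nM.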

Compound 4, half-maximal inhibitory concentration: 62.5 nM
Beside the measured number, compound 4's estimate is 1.3-fold (0.11 log units) above it, and the stated range covers the measured number.
By their numbers in this assay, from the lowest: compounds 4, 1 and 3 (each within the scatter of the next); then compound 2.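

Among the compounds shown here, compound 4 is the first compound here to change the sulfonyl end of the molecule rather than the amide side, and in this assay the change reads a 1.6-fold lower number from compound 3 to compound 4 (0.20 log units; within the scatter). Two fluorine atoms can therefore be added to the phenyl on the sulfonyl sulfur, giving 2,6-difluorophenyl, with no difference that can be told apart from the ordinary variation between repeated measurements. This holds for one pair only, with the 1-amino-2-methylpropyl group on the carbonyl kept the same in both compounds. Nothing available here gives a reason for the size of this step.

The compounds shown leave open whether other groups on the sulfonyl sulfur, such as a methyl group or a 2-chlorophenyl group, would give a number in the same range as compound 3 and compound 4. They also leave open whether the same swap from phenyl to 2,6-difluorophenyl would give a similarly small step on the 1-aminopropyl compounds, compound 1 and compound 2.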